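The source may report more compounds than this note shows. Statements on the series, on what has been measured and on what is new or still open speak of the compounds shown alone.

Among the measured compounds shown here, in an assay on CHO-K1 cells for antagonist activity at transient receptor potential cation channel subfamily V member 1 (Homo sapiens), read by FLIPR (a higher number here means a weaker inhibitor, a lower number a stronger inhibitor), compound 2 `CC(C)CCSc1nc(C(F)(F)F)ccc1CNC(=O)C(C)c1ccc(NS(C)(=O)=O)c(F)c1` gives 0.7 nM, the lowest of the two numbers measured so far. For the measured compounds named here, compound 1 `CCCCCSc1nc(C(F)(F)F)ccc1CNC(=O)C(C)c1ccc(NS(C)(=O)=O)c(F)c1` gives 2.5 nM, and the only measured step at this site is a 3.6-fold lower number from compound 1 to compound 2 (0.55 log units; beyond the scatter). Compound 3 `CC(C(=O)NCc1ccc(C(F)(F)F)nc1SCCOc1ccccc1)c1ccc(NS(C)(=O)=O)c(F)c1` differs from compound 2 by phenoxy in place of isopropyl on a saturated chain carbon, two bonds along the chain from a sulfur. That one step is modest in size, and a phenoxy group is a larger change than the branching it describes, so the expected step of a 2.1-fold higher number from compound 2 to compound 3 (0.33 log units; beyond the scatter) is small, with direction uncertain and a drift toward a higher number somewhat more likely. Compound 3 is therefore estimated at 1.5 nM, within 0.4 nM to 6 nM.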

Compound 3, inhibition constant: 2.3 nM
The estimate for compound 3 lay 1.5-fold (0.19 log units) below the measured number; measured number inside the range.
By their numbers in this assay, from the lowest: compound 2; then compounds 3 and 1 (each within the scatter of the next).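

In this assay, exchanging isopropyl for phenoxy gives a 3.3-fold higher number from compound 2 to compound 3 (0.52 log units; beyond the scatter) and so gives up the gain seen with the branched chain, yet this much larger end with an aromatic ring is still accepted. Against the unbranched chain, phenoxy gives a 1.1-fold lower number from compound 1 to compound 3 (0.04 log units; within the scatter) and the two cannot be told apart. Nothing measured here gives a reason for either step.

The compounds shown do not separate the oxygen from the ring in the 2-phenoxyethyl chain, which an all-carbon phenylpropyl chain could do. Also open, on these data alone, is whether a fluorine or methoxy group on the phenoxy ring would shift the number.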